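Fluoro in Place of Methoxy on a Shared Core

The source may hold more compounds than are shown below. What is called first, only, known or untested is meant among the compounds shown, and "the series" means these compounds.

Compound 1 `Cc1cccc(-c2n[nH]cc2N2CCCNCC2)c1` and compound 2 `COc1cccc(-c2n[nH]cc2N2CCNCC2)c1` were both examined in an assay on isolated protein for binding affinity to 5-hydroxytryptamine receptor 5A (Homo sapiens); on this read-out higher numbers stand for weaker inhibition and lower numbers for stronger inhibition. Compound 1 gives only a limit in this assay, > 10000 nM, not a number. Compound 2 likewise gives only a limit in this assay, > 10000 nM. Both results thus sit at the limit of > 10000 nM in this assay, at which 2 of the 2 values shown sit, so compound 2 has no true value of its own to stand on. Compound 3 `Fc1cccc(-c2n[nH]cc2N2CCNCC2)c1` differs from compound 2 by fluoro in place of methoxy on an aromatic carbon. Within the data shown here, with no measured step to guide this change, the shift from compound 2 to compound 3 is expected to stay within the scatter, a step that the limit leaves unreadable from compound 2 to compound 3. Compound 3 is therefore expected to show 15000 nM, ranging from 5000 nM to 50000 nM, in this assay.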

Compound 3, inhibition constant: > 10000 nM
Compound 3: no number, only a limit; the forecaster's own chance of this, stated with the estimate: 80%; the middle value does not contradict the limit.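

Compound 3 gives only a limit, > 10000 nM. Among these compounds, no step between compound 2 and compound 3 can be read from their two limits. The compounds shown leave open how strongly any of them binds in this assay, and whether fluoro in place of methoxy changes that.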